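The source may hold more compounds than are shown below. What is called first, only, known or untested is meant among the compounds shown, and "the series" means these compounds.

Three compounds share one core and differ only in the group on the ring nitrogen. In a functional assay on K562 cells (Homo sapiens) for antiproliferative activity, read by MTT assay, with a stated time of 48 h (on this read-out higher numbers stand for weaker inhibition and lower numbers for stronger inhibition), compound 1 `CCN1C(=O)C(=O)c2cc(-c3ccc(OC)cc3)ccc21` gives 2200 nM, and compound 2 `C=CCN1C(=O)C(=O)c2cc(-c3ccc(OC)cc3)ccc21` gives 390 nM, a step of a 5.6-fold lower number from compound 1 to compound 2 (0.75 log units; beyond the scatter). Compound 3 `COc1ccc(-c2ccc3c(c2)C(=O)C(=O)N3c2ccc(OC)cc2)cc1` reaches only a limit in this assay, namely > 10000 nM. Compound 3 therefore stands at the weak end of the three, sitting at the limit of > 10000 nM in this assay, at which 1 of the 3 values shown sits. Compound 4 `COc1ccc(-c2ccc3c(c2)C(=O)C(=O)N3Cc2ccc(Cl)c(Cl)c2)cc1` alters compound 3 by 3,4-dichlorobenzyl in place of 4-methoxyphenyl on an amide-type nitrogen in a ring. Since the steps of an at least 4.5-fold higher number from compound 1 to compound 3 (0.65 log units; beyond the scatter) and an at least 25-fold higher number from compound 2 to compound 3 (1.40 log units; beyond the scatter) both show a small chain on that nitrogen giving a lower number than the 4-methoxyphenyl group, a lower number is expected for compound 4, about an at least 6.6-fold lower number from compound 3 to compound 4 (0.82 log units; beyond the scatter). Compound 4 is estimated at 1500 nM, within 300 nM to 8000 nM.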

Compound 4, half-maximal inhibitory concentration: 430 nM
Estimate against measurement, compound 4: 3.5-fold (0.54 log units) above; low and high end bracket the measured number.
By their numbers in this assay, from the lowest: compounds 2 and 4 (each within the scatter of the next); then compound 1. At a limit, above all of these: compound 3.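

Compound 3 stands only at a limit: the limit of > 10000 nM in this assay, at which 1 of the 4 values shown sits. The 4-methoxyphenyl and 3,4-dichlorobenzyl groups each hold one six-membered aromatic ring of carbon only, yet the change gives an at least 23-fold lower number from compound 3 to compound 4 (1.36 log units; beyond the scatter), so such a ring on this nitrogen does not by itself go with weak inhibition. The 3,4-dichlorobenzyl group also keeps up with the small chains, with a 1.1-fold higher number from compound 2 to compound 4 (0.04 log units; within the scatter) and a 5.1-fold lower number from compound 1 to compound 4 (0.71 log units; beyond the scatter). Still open, going by these compounds, is whether the chlorine atoms or the saturated chain carbon bound to the nitrogen carries this gain; an unsubstituted benzyl group would separate the two.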